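Ring Contraction on the Amine Substituent of Compound 3

A few compounds are considered here, and "the series" means these few. Any claim that something is new, unique, unknown or untested is made for them only; others in the source may bear on it.

Compound 3 `CC1(C)C[C@@H](Nc2cc(NCc3cnccc3C(F)(F)F)ncc2C#N)CC[C@@H]1O` gives 2400 nM in an assay on isolated protein for inhibition of protein kinase C delta type (Homo sapiens), read by TR-FRET, with a stated time of 2 h (on this read-out lower numbers stand for stronger inhibition and higher numbers for weaker inhibition), the highest of the three numbers measured. Compound 1 `N#Cc1cnc(NCc2cnccc2C(F)(F)F)cc1NC[C@H]1CC[C@H](O)CC1` gives 2000 nM, and a 1.2-fold higher number from compound 1 to compound 3 (0.08 log units; within the scatter). Compound 2 `CC1(C)C[C@H](Nc2cc(NCc3cnccc3C(F)(F)F)ncc2C#N)CC[C@@H]1O` gives 500 nM; a 4.8-fold higher number from compound 2 to compound 3 (0.68 log units; beyond the scatter), a step that rests on (the fact that compounds 2 and 3 differ only in the configuration as drawn). Compound 4 `CC1(C)[C@@H](Nc2cc(NCc3cnccc3C(F)(F)F)ncc2C#N)C[C@@H]1C(N)=O` carries 3-carbamoyl-2,2-dimethylcyclobutyl in place of 4-hydroxy-3,3-dimethylcyclohexyl on a nitrogen on an aromatic ring. Every measured step alters this same substituent: a 4.0-fold lower number from compound 1 to compound 2 (0.60 log units; beyond the scatter) and the configurational step show that both its shape and its drawn configuration shift the number modestly, yet none of them tests a four-membered ring or a carboxamide. A modest step in either direction is therefore possible, with no firm expectation beyond the scatter. Compound 4 is estimated at 1500 nM, between 300 nM and 7000 nM, corresponding to a 1.6-fold lower number from compound 3 to compound 4 (0.20 log units; within the scatter).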

Compound 4, half-maximal inhibitory concentration: > 10000 nM
Compound 4: no number, only a limit (the forecaster's own chance of this, stated with the estimate: 5%); middle value at least 6.6-fold (0.82 log units) from the limit.
By their numbers in this assay, from the lowest: compound 2; then compounds 1 and 3 (each within the scatter of the next). At a limit, above all of these: compound 4.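

In this assay compound 4 gives > 10000 nM, which is a limit of the assay and not a number: the limit of > 10000 nM in this assay, at which 1 of the 4 values shown sits. On a nitrogen on an aromatic ring, 3-carbamoyl-2,2-dimethylcyclobutyl gives an at least 4.1-fold higher number from compound 3 to compound 4 (0.61 log units; beyond the scatter), an at least 5.0-fold higher number from compound 1 to compound 4 (0.69 log units; beyond the scatter) and an at least 20-fold higher number from compound 2 to compound 4 (1.30 log units; beyond the scatter). Within the data shown here, the earlier changes to this substituent gave only modest steps, so this is the first to show that a change here can cost a large step.

The four-membered ring and the carboxamide enter together, so the compounds shown leave open which of them carries the loss. A hydroxyl on the cyclobutyl ring, or a carboxamide on the cyclohexyl ring, would separate the two.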